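Swapping Methoxy for Hydrogen on Compound 2

The source may hold more compounds than are shown below. What is called first, only, known or untested is meant among the compounds shown, and "the series" means these compounds.

Compound 1 `O=C1C(=Cc2ccc(F)cc2)C(=O)N(c2ccc(Cl)cc2)N1c1ccc(Cl)cc1` gives 23300 nM
Compound 2 `COc1ccccc1C=C1C(=O)N(c2ccc(Cl)cc2)N(c2ccc(Cl)cc2)C1=O` gives 25800 nM

In a functional assay on SMMC-7721 cells (Homo sapiens) for cytotoxicity, read by MTT assay, with a stated time of 72 h (a higher number here means a weaker inhibitor, a lower number a stronger inhibitor), compound 2 stands at 25800 nM within the scatter of compound 1 and so level with it. Compound 3 `O=C1C(=Cc2ccccc2)C(=O)N(c2ccc(Cl)cc2)N1c1ccc(Cl)cc1` follows from compound 2 by one change hydrogen in place of methoxy on an aromatic carbon in which hydrogen takes the place of methoxy on an aromatic carbon. For the measured compounds named here, the only measured step bearing on this is a 1.1-fold higher number from compound 1 to compound 2 (0.04 log units; within the scatter) and it stayed within the scatter. No step beyond the scatter is therefore expected in this assay for this change. The estimate means a 1.0-fold lower number from compound 2 to compound 3 (0.01 log units; within the scatter) as the expected step. Compound 3 is estimated at 25000 nM with 12000 nM to 50000 nM as its expected range.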

Compound 3, half-maximal inhibitory concentration: 26200 nM
Beside the measured number, compound 3's estimate is 1.0-fold (0.02 log units) below it; low and high end bracket the measured number.
By their numbers in this assay, from the lowest: compounds 1, 2 and 3 (each within the scatter of the next).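

In this assay, the step with hydrogen in place of methoxy is a 1.0-fold higher number from compound 2 to compound 3 (0.01 log units; within the scatter), and the step with hydrogen in place of fluoro is a 1.1-fold higher number from compound 1 to compound 3 (0.05 log units; within the scatter). The earlier compounds shown here compared two substituted rings only; with the unsubstituted phenyl of compound 3 as a reference, neither methoxy nor fluoro separates from hydrogen here. No evidence on the origin of this flat result is available. Still open, from the compounds shown here alone, is whether an amine, a carboxylic acid or a longer chain on this ring would give a step beyond the scatter.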